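The compounds below may be only part of what the source reports. "The series", "measured", "known", "first", "only" and "open" are said of these compounds alone.

Four compounds from one study are compared here. Compound 1 `CC(C)(C)OC(=O)NCCCCNCCCN(Cc1ccsc1)Cc1ccsc1` carries a tert-butoxycarbonyl on one amine nitrogen, and compound 3 `NCCCCNCCCN(Cc1ccsc1)Cc1ccsc1` is the same molecule with hydrogen in its place. Compound 2 `CC(C)(C)OC(=O)NCCCCNCCCN(Cc1ccc(-c2ccccc2)cc1)Cc1ccc(-c2ccccc2)cc1` and compound 4 `NCCCCNCCCN(Cc1ccc(-c2ccccc2)cc1)Cc1ccc(-c2ccccc2)cc1` form a matching pair built on a different core; the difference between the two cores is not broken down here.

In an ADME assay on RAW264.7 cells (Mus musculus) for cytotoxicity, read by resazurin assay, with a stated time of 48 h (a lower number here means that less compound is tolerated, a higher number that more compound is tolerated), compound 1 gives 16400 nM, and compound 3 gives 52800 nM. The change between them, (hydrogen in place of tert-butoxycarbonyl on an amine nitrogen), brought a 3.2-fold higher number from compound 1 to compound 3 (0.51 log units; beyond the scatter). For compound 2 in this assay only a limit is recorded, > 100000 nM. Compound 2 thus sits at the limit of > 100000 nM in this assay, at which 1 of the 3 values shown sits.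

Compound 4 stands to compound 2 as compound 3 stands to compound 1: the change is hydrogen in place of tert-butoxycarbonyl on an amine nitrogen, the same change at the same kind of place. Since compound 2 already sits at that limit, and the change raised the number once before because a 3.2-fold higher number from compound 1 to compound 3 (0.51 log units; beyond the scatter), compound 4 is expected to sit at or above the limit as well, most likely again reported only as a limit. The step expected here is a step that the limit leaves unreadable from compound 2 to compound 4. Compound 4 is therefore estimated at 200000 nM, with a likely range from 60000 nM to 600000 nM, though the assay may well return no number for it at all.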

Compound 4, half-maximal cytotoxic concentration: 4200 nM
The estimate for compound 4 lay 48-fold (1.68 log units) above the measured number; the whole stated range lies above it.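

Compound 2 is recorded only as a limit of the assay, > 100000 nM. In this assay, putting hydrogen in place of tert-butoxycarbonyl on an amine nitrogen gave an at least 23-fold lower number from compound 2 to compound 4 (1.37 log units; beyond the scatter), and set beside the earlier step, the same change does not carry over from one core to the other, not even in direction: the same change on two cores in this assay, a 3.2-fold higher number (0.51 log units; beyond the scatter) from compound 1 to compound 3 and an at least 23-fold lower number (1.37 log units; beyond the scatter) from compound 2 to compound 4, at least 76-fold (1.88 log units) apart, beyond the scatter of two such steps With just two matched pairs, this shows that the outcome of the change on the core of compound 1 would have been a poor guide to its outcome on the core of compound 2, but it does not show why the two cores part ways, nor how the change would behave on any further core.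

From the compounds shown here alone, it remains open whether a smaller group on the same amine nitrogen, such as acetyl or methyl, would follow tert-butoxycarbonyl or hydrogen on each of the two cores. It also remains open which part of the core of compound 2 sets the direction of the change, and a core carrying one plain benzyl group in place of the larger groups shown could help to settle that.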